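Swapping the benzyl group for a branched chloro analogue

The source may report more compounds than this note shows. Statements on the series, on what has been measured and on what is new or still open speak of the compounds shown alone.

Of the compounds shown here, two of a shared core have been tested in an assay on isolated protein for inhibition of G protein-coupled receptor kinase 6 (Homo sapiens), read by scintillation counting, radiometric assay and 33P incorporation, with a stated time of 80 min, in the presence of a further agent that is not named here; a higher number here means a weaker inhibitor, a lower number a stronger inhibitor. Compound 1 `CCc1cc(Nc2nc(N[C@@H](C)c3ccc(F)cc3)nc3cccc(F)c23)n[nH]1` gives 41 nM. Compound 2 `CCc1cc(Nc2nc(NCc3ccc(F)cc3)nc3ccccc23)n[nH]1` gives 250 nM, the higher of the two numbers, and its gap to compound 1 lies beyond the usual scatter. Compound 3 `CCc1cc(Nc2nc(N[C@@H](C)c3ccc(Cl)cc3)nc3ccccc23)n[nH]1` is a new analogue of compound 2, differing by 1-(4-chlorophenyl)ethyl in place of 4-fluorobenzyl on a nitrogen on an aromatic ring. Since compound 1 also carries a branched group on that nitrogen and gives 41 nM, a moderate drop in number is expected, a 2.8-fold lower number from compound 2 to compound 3 (0.44 log units; beyond the scatter). Compound 3 is therefore estimated at 90 nM, within a range from 30 nM to 300 nM.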

Compound 3, half-maximal inhibitory concentration: 70 nM
Estimate against measurement, compound 3: 1.3-fold (0.11 log units) above; low and high end bracket the measured number.
By their numbers in this assay, from the lowest: compounds 1 and 3 (each within the scatter of the next); then compound 2.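

On a nitrogen on an aromatic ring, 1-(4-chlorophenyl)ethyl in place of 4-fluorobenzyl gives a 3.6-fold lower number from compound 2 to compound 3 (0.55 log units; beyond the scatter) and so shows, in a single-place change, that the number responds to the group held at this position. That swap changes two things at once, fluorine to chlorine and the added branch with its defined stereocentre, and the step cannot divide its size between them. Nothing available explains the drop. Open, going by these compounds, is where 4-chlorobenzyl would fall, which could separate those two changes. On these data alone, the mirror-image form of the branched group is equally open.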